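Removing tert-Butoxycarbonyl on Two Related Compounds

A few compounds are considered here, and "the series" means these few. Any claim that something is new, unique, unknown or untested is made for them only; others in the source may bear on it.

Compound 1 `CC(C)(C)OC(=O)CC[C@H](NC(=O)c1cc(Cl)ccc1OCCNC(=O)OC(C)(C)C)C(=O)Nc1ccc([N+](=O)[O-])cc1Cl` gives > 10000 nM in a functional assay on MDA-MB-231 cells (Homo sapiens) for inhibition, read by MTT assay, with a stated time of 72 h; a lower number here means a stronger inhibitor, a higher number a weaker inhibitor.
Compound 2 `CC(C)(C)OC(=O)CC[C@H](NC(=O)c1cc(Cl)ccc1OCCN)C(=O)Nc1ccc([N+](=O)[O-])cc1Cl` gives 5990 nM in this assay.
Compound 3 `CC(C)[C@H](NC(=O)c1cc(Cl)ccc1OCCNC(=O)OC(C)(C)C)C(=O)Nc1cc(F)cc(C(F)(F)F)c1` gives 7870 nM in this assay.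

For compound 1 that value is a limit of the assay, not a number. Compound 2 differs from compound 1 by hydrogen in place of tert-butoxycarbonyl on an amine nitrogen, and this change gave an at least 1.6-fold lower number from compound 1 to compound 2 (0.22 log units; that floor lies within the scatter). Compound 3 carries a different core; how its core differs from that of compound 1 is not broken down here. Compound 4 `CC(C)[C@H](NC(=O)c1cc(Cl)ccc1OCCN)C(=O)Nc1cc(F)cc(C(F)(F)F)c1` has not yet been measured in this assay. It differs from compound 3 by hydrogen in place of tert-butoxycarbonyl on an amine nitrogen, the same change at the same place as before. Resting on an at least 1.6-fold lower number from compound 1 to compound 2 (0.22 log units; that floor lies within the scatter), compound 4 is expected to show a 1.6-fold lower number from compound 3 to compound 4 (0.20 log units; within the scatter) in this assay. Compound 4 is therefore estimated at 5000 nM, most likely between 2000 nM and 15000 nM.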

Compound 4, half-maximal inhibitory concentration: 4340 nM
Estimate against measurement, compound 4: 1.2-fold (0.06 log units) above; the range from low to high includes it.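

Swapping tert-butoxycarbonyl for hydrogen on the amine nitrogen of the second core gives a 1.8-fold lower number from compound 3 to compound 4 (0.26 log units; within the scatter) in this assay. Set side by side, the two steps read: the same change on two cores in this assay, an at least 1.6-fold lower number (0.22 log units; that floor lies within the scatter) from compound 1 to compound 2 and a 1.8-fold lower number (0.26 log units; within the scatter) from compound 3 to compound 4; the limit leaves it open whether they differ Neither step lies beyond the usual scatter, so these compounds show neither a real effect of the change on either core nor that its size carries over unchanged from one core to the other.

The compounds shown leave open whether a different group on this amine nitrogen, such as an acetyl group, or a longer chain in place of 2-aminoethyl, would move the number beyond the scatter. They also leave open how the same change behaves on a third core.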